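The source may report more compounds than this note shows. Statements on the series, on what has been measured and on what is new or still open speak of the compounds shown alone.

Compound 1 `Cc1ccccc1C[C@H]1C(=O)OC[C@@H]1Cc1ccccc1` gives 57000 nM. Compound 2 `O=C1OC[C@H](Cc2ccccc2)[C@H]1Cc1ccccc1C(F)(F)F` gives 37000 nM.

Among the compounds with values here, in a functional assay on HL-60 cells (Homo sapiens) for cytotoxicity, read by WST assay, with a stated time of 48 h (on this read-out lower numbers stand for an effect already at smaller amounts and higher numbers for an effect only at larger amounts of compound), compound 1 stands at the highest of the two numbers measured so far; its nearest neighbour is compound 2, and the step of a 1.5-fold lower number from compound 1 to compound 2 (0.19 log units; within the scatter) stays within the scatter of the assay. Compound 3 `O=C1OC[C@H](Cc2ccccc2)[C@H]1Cc1cccc(F)c1` has not been measured yet. It differs from compound 1 by 3-fluorophenyl in place of 2-methylphenyl on a saturated chain carbon bound to a saturated ring carbon. Within the data shown here, the only measured step, which replaced the methyl of compound 1 by trifluoromethyl on the same aromatic carbon, moved the number only within the scatter, so a change on this aromatic ring has so far been of little consequence. Among the measured compounds shown here, no measured step exchanges the whole 2-methylphenyl group, so the expectation for compound 3 rests on that single comparison. For compound 3 in this assay a value of about 45000 nM is expected, in the range 15000 nM to 130000 nM, which means an expected step of a 1.3-fold lower number from compound 1 to compound 3 (0.10 log units; within the scatter) of no more than the scatter.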

Compound 3, half-maximal effective concentration: 75000 nM
For compound 3 the middle estimate is 1.7-fold (0.22 log units) below the measured one; the range from low to high includes it.
By their numbers in this assay, from the lowest: compounds 2, 1 and 3 (each within the scatter of the next, the first and the last beyond it).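

In this assay the step on exchanging the whole 2-methylphenyl group for 3-fluorophenyl, on a saturated chain carbon bound to a saturated ring carbon, is a 1.3-fold higher number from compound 1 to compound 3 (0.12 log units; within the scatter) and so cannot be told apart from repeat-measurement noise. The earlier step changed only the substituent on the ring, whereas this one replaces the entire aromatic group, and the number still does not move measurably. No information is available that would explain this result.

All the compounds shown carry a six-membered aromatic ring of carbon only at this place, so it stays open whether an amine, a carboxylic acid or a longer chain there would shift the number beyond the scatter. Going by these compounds, the effect of changes elsewhere on the shared core also remains open.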